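The source may hold more compounds than are shown below. What is called first, only, known or untested is meant among the compounds shown, and "the series" means these compounds.

Working notes on the series.

Of the compounds shown here, three have been measured in an assay on isolated protein for inhibition of Amine oxidase [flavin-containing] A (Homo sapiens), read by Amplex Red, with a stated time of 15 min, tested at 100 uM; on this read-out lower numbers stand for less inhibition and higher numbers for more inhibition at the one concentration tested (going by the name of the read-out). Compound 1 `CC(=O)c1ccc(OCc2ccccc2C)cc1` gives 42.9% in this assay. Compound 3 `CC(=O)c1cccc(OCc2ccc(F)cc2)c1` gives 49.6% in this assay. Compound 2 `CC(=O)c1cccc(OCc2cccc(F)c2)c1` gives 31% in this assay, the lowest of the three numbers; its nearest neighbour is compound 1, whose number lies higher by more than the scatter, and compound 3 lies higher still, also beyond the scatter. For the measured compounds named here, no pair of these three differs in one place only, so no single step between measured compounds can be read off.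

Compound 4 `CC(=O)c1cccc(OCc2cccc(Br)c2)c1` has not yet been measured in this assay. It differs from compound 2 in one place: bromo in place of fluoro on an aromatic carbon. Going by the values given here, with no measured halogen-for-halogen step, the expectation for the step from compound 2 to compound 4 is a small one, upward if anything, and not clearly beyond the scatter, a number 9 percentage points higher from compound 2 to compound 4 (within the scatter). On that basis compound 4 is estimated to give 40% in this assay, with a range of 22% to 58%.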

Compound 4, a percentage reported as inhibition, at one concentration (the size of the read-out at that concentration, not a potency): 49.1%
For compound 4 the middle estimate is 9.1 percentage points below the measured one; the measured number falls inside the stated range.
By their numbers in this assay, from the lowest: compound 2; then compounds 1, 4 and 3 (each within the scatter of the next).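

In this assay the series now has its first step in one place: it is a number 18.1 percentage points higher from compound 2 to compound 4 (beyond the scatter) for bromo in place of fluoro on an aromatic carbon, meta to a large group. This position is therefore not indifferent to which halogen it carries, as an exchange of one heavy atom, with no change in hydrogen-bond donors, acceptors or net charge, moves the number beyond the scatter. Nothing at hand bears on what lies behind this step.

The compounds shown leave open what chloro, a methoxy group or an amine would give at this position, and whether the same exchange would give a similar step elsewhere on the ring. With one concentration only, the step also leaves any difference in potency open.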